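Phenyl in Place of Hydrogen on the Oxygen of Compound 1

The source may hold more compounds than are shown below. What is called first, only, known or untested is meant among the compounds shown, and "the series" means these compounds.

Measured so far in a functional assay on ileum for inhibition of histamine H1 receptor (Cavia porcellus); a lower number here means a stronger inhibitor, a higher number a weaker inhibitor:
compound 1 `CN1CCN(c2nc3ccccc3n2CCO)CC1`: 410 nM
compound 2 `CCCCCN1CCN(c2nc3ccccc3n2CCOCC)CC1`: 30 nM
compound 3 `C=CCOCCn1c(N2CCCN(C)CC2)nc2ccccc21`: 10 nM

Among these three, compound 1 gives the highest number in this assay, with 410 nM; compound 2 gives 30 nM and compound 3 gives 10 nM, both beyond the scatter below compound 1. Compound 4 `CN1CCN(c2nc3ccccc3n2CCOc2ccccc2)CC1` has not yet been measured in this assay. It differs from compound 1 in one place: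
phenyl in place of hydrogen on an oxygen on a saturated carbon
For the measured compounds named here, no direct step between two measured compounds shows this change. The two measured compounds with a group other than hydrogen on that oxygen give lower numbers than compound 1, so a step toward a lower number is expected, of the size a 9.1-fold lower number from compound 1 to compound 4 (0.96 log units; beyond the scatter). Compound 4 is expected to give about 45 nM in this assay, within a range from 12 nM to 180 nM.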

Compound 4, half-maximal inhibitory concentration: 6.9 nM
Compound 4: the middle estimate sits 6.5-fold (0.81 log units) above what was measured; the measured number lies below the stated range.
By their numbers in this assay, from the lowest: compounds 4 and 3 (each within the scatter of the next); then compound 2; then compound 1.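

In this assay, phenyl in place of hydrogen on the oxygen gives a 59-fold lower number from compound 1 to compound 4 (1.77 log units; beyond the scatter), a large step toward stronger inhibition. For the compounds shown here, this is the first step at this position with the rest of compound 1 left unchanged, as compound 2 and compound 3 each differ from it in more than one place. No measurement shown explains the size of this step.

The compounds shown leave open whether an aromatic ring is needed here, or whether a methyl or a benzyl on the same oxygen would give a similar step. As far as these compounds go, how a chlorine or a methoxy on the phenyl would change the number also remains open.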